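A few compounds are considered here, and "the series" means these few. Any claim that something is new, unique, unknown or untested is made for them only; others in the source may bear on it.

Measured so far in an assay on membranes from HeLa cells for displacement of a labelled ligand from adenosine receptor A3 (Homo sapiens), read by scintillation counting, with a stated time of 180 min, tested at 1 uM; a lower number here means less inhibition, a higher number more inhibition at the concentration tested (going by the name of the read-out):

Compound 1, `CCCOC(=O)C1=C(C)NC(=S)NC1c1ccco1`, gives 1% in this assay.
Compound 2, `CCCOC(=O)C1=C(C)NC(=S)NC1c1ccoc1`, gives 3% in this assay.
Compound 3, `COC(=O)C1=C(C)NC(=S)NC1c1cccs1`, gives 1% in this assay.

Compound 3 stands level with compound 1 at the digits printed, and its gap to compound 2 lies within the scatter; all three numbers sit close to the floor of what this assay can report. Within the data shown here, the only measured step, a number 2 percentage points higher from compound 1 to compound 2 (within the scatter), concerns a group on a saturated ring carbon and stays within the scatter.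

Compound 4, `CCCOC(=O)C1=C(C)NC(=S)NC1c1cccs1`, differs from compound 3 in one place: ethyl in place of hydrogen on a saturated chain carbon bound to an oxygen next to a carbonyl group. Among the measured compounds shown here, no measured step varies this part of the molecule, so the expectation rests on the flat picture that the three measured numbers give. Compound 4 is therefore expected to give 2% in this assay, with a range from 0% to 12%. This estimate means a step of a number 1 percentage points higher from compound 3 to compound 4 (within the scatter), which is expected to stay within the scatter.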

Compound 4, a percentage reported as inhibition, at one concentration (the size of the read-out at that concentration, not a potency): 10%
For compound 4 the middle estimate is 8 percentage points below the measured one, within the range that was stated.
By their numbers in this assay, from the lowest: compounds 1, 3, 2 and 4 (each within the scatter of the next).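

Swapping methoxycarbonyl for propoxycarbonyl gives a number 9 percentage points higher from compound 3 to compound 4 (within the scatter) in this assay, which is the first measured change at this part of the molecule, and its size cannot be told apart from the usual variation between repeats. With the propoxycarbonyl group held constant, thiophen-2-yl in place of furan-3-yl gives a number 7 percentage points higher from compound 2 to compound 4 (within the scatter), and thiophen-2-yl in place of furan-2-yl gives a number 9 percentage points higher from compound 1 to compound 4 (within the scatter), so neither change is shown to alter the read-out at this concentration. Nothing available offers an explanation for these numbers.

As far as these compounds go, it stays open whether a longer chain such as butoxycarbonyl, or a carboxylic acid in place of the ester, would give a change beyond the scatter. The same question stands for a phenyl group on the saturated ring carbon, and a reading at one concentration gives no potency for any of these compounds.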